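The compounds below may be only part of what the source reports. "The series", "measured", "known", "first", "only" and "open" are said of these compounds alone.

Working notes on the series. Compound 1 (`CC1=C2CC(C)(C)/C=C/C/C(C)=C\C3=C[C@H](C)C[C@]3(O2)C1=O`) gives 26000 nM in an ADME assay on BJ cells (Homo sapiens) for cytotoxicity, read by CellTiter-Glo, with a stated time of 72 h; on this read-out higher numbers stand for an effect only at larger amounts of compound and lower numbers for an effect already at smaller amounts. Going by the values given here, compound 2 (`CC1=C2CC(C)(C)/C=C/C(=O)/C(C)=C\C3=C[C@H](C)C[C@]3(O2)[C@@]1(O)C#N`) gives 26000 nM and compound 3 (`CC(=O)O[C@@H]1/C=C/C(C)(C)CC2=C(C)C(=O)[C@]3(C[C@@H](C)C=C3/C=C\1C)O2`) gives 26000 nM, so compound 1 stands level with both at the digits available, and the series so far shows no spread.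

Compound 4 (`CC1=C2CC(C)(C)/C=C/[C@H](OC(=S)Sc3ccccc3)/C(C)=C\C3=C[C@H](C)C[C@]3(O2)C1=O`) has not yet been measured. Its change from compound 1 is a group of 10 heavy atoms (7 carbon, 1 oxygen, 2 sulfur; one six-membered aromatic ring of carbon only) in place of a hydrogen atom, on a saturated ring carbon.

Among the compounds with values here, one measured step bears on this change: acetoxy in place of hydrogen, also on a saturated ring carbon, gave no change at the digits printed from compound 1 to compound 3 (within the scatter). That substitution left this assay unmoved, but it is a single case. Within the data shown here, the group entering compound 4 is larger, and it carries sulfur and an aromatic ring, which no measured compound in this set has at that kind of position. Among the measured compounds shown here, the data therefore offer no direct precedent for such a group.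

No shift beyond the scatter is expected, although the uncertainty extends further towards smaller amounts of compound than towards larger ones. The expected step is a 1.2-fold lower number from compound 1 to compound 4 (0.07 log units; within the scatter). For compound 4 the estimated value in this assay is 22000 nM, with an expected range of 9000 nM to 30000 nM.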

Compound 4, half-maximal effective concentration: 26000 nM
Compound 4: the middle estimate sits 1.2-fold (0.07 log units) below what was measured; the measured number falls inside the stated range.
By their numbers in this assay, from the lowest: compounds 1, 2, 3 and 4 (each within the scatter of the next).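

In this assay, placing the group of 10 heavy atoms, with its one six-membered aromatic ring of carbon only, on a saturated ring carbon gives no change at the digits printed from compound 1 to compound 4 (within the scatter). Acetoxy had been the only substitution of this kind on record, with no change at the digits printed from compound 1 to compound 3 (within the scatter), and the series now holds a second, much larger group carrying sulfur and an aromatic ring that also leaves the read-out unmoved, so among these compounds neither the added heavy atoms nor the aromatic ring shifts the number beyond the scatter. No available measurement gives a reason for this flat result.

All four compounds lie within the scatter of one another, so the compounds shown include no group at a saturated ring carbon that moves the number in this assay, and the limits of this flat behaviour remain undefined. Whether an amine or a carboxylic acid on that carbon, both absent from the compounds shown, would leave the read-out equally unmoved remains open.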